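Chloro for Hydrogen on the Aromatic Ring of Compound 2

A few compounds are considered here, and "the series" means these few. Any claim that something is new, unique, unknown or untested is made for them only; others in the source may bear on it.

Compound 1 `CC1=CC[C@H](C(C)(C)NC(=S)NN)CC1` is the smallest member of the set; in a functional assay on NCI/ADR-RES cells (Homo sapiens) for inhibition, read by sulforhodamine B assay, with a stated time of 48 h (a higher number here means a weaker inhibitor of growth, a lower number a stronger inhibitor of growth), compound 1 gives > 100000 nM, which is a limit of the assay and not a number. Compound 2 `CC1=CC[C@H](C(C)(C)NC(=S)N/N=C/c2ccccc2)CC1` adds an unsubstituted phenyl. In this assay compound 2 gives > 100000 nM, again only a limit (the limit of > 100000 nM in this assay, at which 2 of the 3 values shown sit). Compound 3 `CC1=CC[C@H](C(C)(C)NC(=S)N/N=C/c2ccccc2O)CC1` gives 10900 nM in this assay, and the step of an at least 9.1-fold lower number from compound 2 to compound 3 (0.96 log units; beyond the scatter) shows a hydroxy in place of hydrogen carrying the number below the limit. Compound 4 `CC1=CC[C@H](C(C)(C)NC(=S)N/N=C/c2ccccc2Cl)CC1` differs from compound 2 by chloro in place of hydrogen on an aromatic carbon. Within the data shown here, only that one measured step bears on it, and it concerns a different group, so the expected step of an at least 1.6-fold lower number from compound 2 to compound 4 (0.22 log units; that floor lies within the scatter) is modest and uncertain. Compound 4 is therefore estimated at 60000 nM, ranging from 15000 nM to 200000 nM.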

Compound 4, concentration for total growth inhibition: > 100000 nM
Compound 4 ended at the assay's limit; the forecaster's own chance of this, stated with the estimate: 50%; middle value at least 1.6-fold (0.22 log units) away from the limit.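

In this assay chloro in place of hydroxy at this aromatic carbon, ortho to a large group, gives an at least 9.1-fold higher number from compound 3 to compound 4 (0.96 log units; beyond the scatter) and so does not keep the lower number seen with hydroxy. Compound 4 gives > 100000 nM as a limit of the assay and not a number, so the step from compound 2 to compound 4 cannot be read. The set now gathers at that limit: the limit of > 100000 nM in this assay, at which 3 of the 4 values shown sit.

Open, as far as these compounds go, is whether an amine or a methoxy group at this position would follow hydroxy or chloro. Also open, from the compounds shown here alone, is whether hydroxy elsewhere on the aromatic ring would keep the lower number.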